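Estimating compound 4 without a number for compound 3

The source may hold more compounds than are shown below. What is called first, only, known or untested is meant among the compounds shown, and "the series" means these compounds.

Compound 1 `OC[C@H]1O[C@@H](n2cnc3c(NCc4ccc(Cl)cc4)ncnc32)[C@H](O)[C@@H]1O`: 10200 nM
Compound 2 `OC[C@H]1O[C@@H](n2cnc3c(NCc4ccccc4Br)ncnc32)[C@H](O)[C@@H]1O`: 12300 nM
Compound 3 `OC[C@H]1O[C@@H](n2cnc3c(NCc4cccc(O)c4O)ncnc32)[C@H](O)[C@@H]1O`: "not determined" (no result reported)

In a functional assay on CCRF-CEM cells (Homo sapiens) for antiproliferative activity, with a stated time of 72 h (a lower number here means a stronger inhibitor, a higher number a weaker inhibitor), compound 3 has no single number: its entry reads "not determined" (no result reported). Compound 4 `Cc1cccc(CNc2ncnc3c2ncn3[C@@H]2O[C@H](CO)[C@@H](O)[C@H]2O)c1O` differs from compound 3 by methyl in place of hydroxy on an aromatic carbon, ortho to a hydroxy group (methyl in place of hydroxy on an aromatic carbon). Among the measured compounds shown here, no measured step covers this swap. For the measured compounds named here, the only measured step, a 1.2-fold higher number from compound 1 to compound 2 (0.08 log units; within the scatter), is a different swap and lies within the scatter. With no starting number, neither the size nor the direction of a step can be expected in this assay. The best guide is the level of compound 1 at 10200 nM and compound 2 at 12300 nM. The expected value for compound 4 is 9000 nM, with an estimated range of 2000 nM to 40000 nM.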

Compound 4, half-maximal inhibitory concentration: 900 nM
The estimate for compound 4 lay 10-fold (1.00 log units) above the measured number; measured number below the stated range.
By their numbers in this assay, from the lowest: compound 4; then compounds 1 and 2 (each within the scatter of the next).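

In this assay, among the compounds shown here, the 2-hydroxy-3-methylphenyl group of compound 4 brings the first change beyond the scatter, with a 14-fold lower number from compound 2 to compound 4 (1.14 log units; beyond the scatter) and an 11-fold lower number from compound 1 to compound 4 (1.05 log units; beyond the scatter). The swap from 4-chlorophenyl to 2-bromophenyl had moved nothing beyond the scatter, so this new result shows that changing this ring can shift the number strongly. No measurement shown explains the drop.

The step from hydroxy to methyl cannot be read, as compound 3 has no number. As far as these compounds go, whether an ethyl, a methoxy or an amine in the methyl's place would hold this level stays open.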